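Shortening the acyl chain on the shared core

The source may hold more compounds than are shown below. What is called first, only, known or untested is meant among the compounds shown, and "the series" means these compounds.

Among the measured compounds shown here, compound 2 `CCCCC(=O)N1CCN(c2nnc3nncn3n2)CC1` gives 1720 nM in a functional assay on BeWo cells (Homo sapiens) for inhibition, read by MTT assay, with a stated time of 72 h (on this read-out higher numbers stand for weaker inhibition and lower numbers for stronger inhibition), the lower of the two numbers so far, though the gap to compound 1 `OCCNc1nnc2nncn2n1`, which gives 3310 nM in this assay, lies within the scatter, so no order between them is claimed. Compound 3 `CCCC(=O)N1CCN(c2nnc3nncn3n2)CC1` differs from compound 2 by hydrogen in place of methyl on a saturated chain carbon, three bonds along the chain from a carbonyl carbon. For the measured compounds named here, no measured pair shows a step of this kind, so nothing beyond the scatter is expected, with at most a slight drift toward weaker inhibition. For compound 3 the expected value in this assay is 2100 nM, within 900 nM to 4800 nM. The step of a 1.2-fold higher number from compound 2 to compound 3 (0.09 log units; within the scatter) is expected to stay within the scatter.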

Compound 3, half-maximal inhibitory concentration: 6730 nM
For compound 3 the middle estimate is 3.2-fold (0.51 log units) below the measured one, outside the stated range (above it).
By their numbers in this assay, from the lowest: compounds 2 and 1 (each within the scatter of the next); then compound 3.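

In this assay, among the compounds shown here, hydrogen in place of methyl on a saturated chain carbon, three bonds along the chain from a carbonyl carbon, gives a 3.9-fold higher number from compound 2 to compound 3 (0.59 log units; beyond the scatter) and so is the first difference that exceeds the scatter. On the shared core, butyl to propyl on the acyl carbonyl goes with weaker inhibition, a modest step from the loss of one carbon. No measurement at hand accounts for this step.

On these data alone, whether a longer chain than butyl would extend or reverse this step remains open, as does the effect of an amine at the chain end. A single step between two compounds establishes no trend along the chain.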